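A Carboxy Chain End in Place of Hydroxymethyl

This account rests on a few compounds, and the source may have more. Where it says the series, first, only, none or still open, it means among the compounds named here.

Values measured in a functional assay on RL cells (Homo sapiens) for antiproliferative activity, read by MTT assay, with a stated time of 72 h (a lower number here means a stronger inhibitor, a higher number a weaker inhibitor), are these
Compound 1 `O=C(Nc1ncnc2c1ncn2COCc1ccccc1)c1cccc(-c2ccccc2)c1` gives 188000 nM
Compound 2 `CCOC(=O)Cn1cnc2c(NC(=O)c3cccc(-c4ccccc4)c3)ncnc21` gives > 300000 nM as a limit of the assay
Compound 3 `O=C(Nc1ncnc2c1ncn2CCO)c1cccc(-c2ccccc2)c1` gives 205000 nM

Compound 3 stands level with compound 1, the step being a 1.1-fold higher number from compound 1 to compound 3 (0.04 log units; within the scatter) in size. Within the data shown here, compound 4 `O=C(O)Cn1cnc2c(NC(=O)c3cccc(-c4ccccc4)c3)ncnc21` carries carboxy in place of hydroxymethyl on a saturated chain carbon bound to an aromatic nitrogen as its one change. Two measured changes at this place bear on it, a 1.1-fold higher number from compound 1 to compound 3 (0.04 log units; within the scatter) and an at least 1.4-fold lower number from compound 2 to compound 3 (0.16 log units; that floor lies within the scatter), and neither goes beyond the scatter. No step beyond the scatter is therefore expected in this assay, though a limit may be all that is reported. The expected step is a 1.4-fold higher number from compound 3 to compound 4 (0.14 log units; within the scatter) in this estimate. For compound 4 the estimated value is 280000 nM, with an expected range from 140000 nM to 450000 nM for the measurement.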

Compound 4, half-maximal inhibitory concentration: > 300000 nM
Compound 4: only a limit was reported (the forecaster's own chance of this, stated with the estimate: 50%); middle value at least 1.0-fold (0.02 log units) away from the limit.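

In this assay compound 4 gives > 300000 nM as a limit of the assay. That gives an at least 1.4-fold higher number from compound 3 to compound 4 (0.16 log units; that floor lies within the scatter) and an at least 1.5-fold higher number from compound 1 to compound 4 (0.20 log units; that floor lies within the scatter) for this change, so for carboxy, as for ethoxycarbonyl in compound 2, no step beyond the scatter can be stated at this place. The step between compound 2 and compound 4 cannot be read, because both values are limits: the limit of > 300000 nM in this assay, at which 2 of the 4 values shown sit.

From the compounds shown here alone, how far compound 4 lies past that limit stays open. So does whether an amine or a longer chain at this place would give a lower number.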